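The compounds below may be only part of what the source reports. "The series", "measured", "known", "first", "only" and "open" are said of these compounds alone.

Compound 2 `CCN(CC)S(=O)(=O)c1ccc(S(=O)(=O)N2CCC[C@@H](C(=O)N3CC[C@H](OC)C3)C2)cc1` carries a (3-methoxypyrrolidin-1-yl)carbonyl group on the shared core. In a functional assay on MIA PaCa-2 cells (Homo sapiens) for inhibition, read by MTT assay, with a stated time of 3 days (on this read-out lower numbers stand for stronger inhibition and higher numbers for weaker inhibition), compound 2 records a limit of > 10000 nM. Its nearest relative, compound 1 `CCN(CC)S(=O)(=O)c1ccc(S(=O)(=O)N2CCC[C@@H](C(=O)N[C@H]3CC[C@@H](OC)CC3)C2)cc1`, differs only in bearing (4-methoxycyclohexyl)amino on the carbonyl carbon. In this assay compound 1 likewise records a limit of > 10000 nM. The step that the two limits leave unreadable from compound 1 to compound 2 cannot be read as a number, since the limit of > 10000 nM in this assay, at which 2 of the 2 values shown sit, is where both values sit. Compound 3 `CCN(CC)S(=O)(=O)c1ccc(S(=O)(=O)N2CCC[C@@H](C(=O)N3CCC(C(F)F)CC3)C2)cc1` is the next member of the series: 4-(difluoromethyl)piperidin-1-yl in place of 3-methoxypyrrolidin-1-yl on a carbonyl carbon. Among the compounds with values here, no measured step bears on this change beyond the two limits, so neither a direction nor a size can be taken from the data. Compound 3 is therefore expected to remain near the same limit, with an estimated step that the limit leaves unreadable from compound 2 to compound 3. Compound 3 is estimated at 15000 nM, within a range from 5000 nM to 50000 nM.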

Compound 3, half-maximal inhibitory concentration: > 10000 nM
Compound 3 gave a limit, no number; the forecaster's own chance of this, stated with the estimate: 75%; the middle value lies beyond the limit too.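

Compound 1, compound 2 and compound 3 each give only a limit, and no step among them can be read in this assay because all three share the same limit: the limit of > 10000 nM in this assay, at which 3 of the 3 values shown sit.

The compounds shown leave open whether any group on this carbonyl carbon gives measurable inhibition, and how these three compounds would rank.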